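Swapping chloro for bromo on two related cores

This account rests on a few compounds, and the source may have more. Where it says the series, first, only, none or still open, it means among the compounds named here.

Measured so far in a functional assay on BGC-823 cells (Homo sapiens) for antiproliferative activity, read by MTT assay, with a stated time of 48 h; a higher number here means a weaker inhibitor, a lower number a stronger inhibitor:
Compound 1, `Clc1ccccc1CSc1nnc(-c2cnccn2)o1`, gives 27700 nM.
Compound 2, `Brc1ccccc1CSc1nnc(-c2cnccn2)o1`, gives 17600 nM.
Compound 3, `Clc1ccc(CSc2nnc(-c3cnccn3)n2-c2ccccc2)cc1`, gives 27700 nM.

Compounds 1 and 2 share one core and differ in a single spot: bromo in place of chloro on an aromatic carbon. That change made a 1.6-fold lower number from compound 1 to compound 2 (0.20 log units; within the scatter), so the two numbers are not really told apart by this assay. Compound 3 is built on a different core; how the two cores differ is not broken down here. Its value sits level with compound 1 at the digits given, and compound 2 is the nearest other number, within the scatter.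

Compound 4, `Brc1ccc(CSc2nnc(-c3cnccn3)n2-c2ccccc2)cc1`, has not yet been measured. It stands to compound 3 as compound 2 stands to compound 1: bromo in place of chloro on an aromatic carbon. The surroundings are not identical, though. In compound 2 the new group sits ortho to a large group, in compound 4 it sits para to a large group, so this is the same kind of change rather than the same change.

Going by the values given here, the only guide is the earlier step, and because it gave a 1.6-fold lower number from compound 1 to compound 2 (0.20 log units; within the scatter), the step from compound 3 to compound 4 is expected to be small as well, about a 1.4-fold lower number from compound 3 to compound 4 (0.14 log units; within the scatter). On that basis compound 4 is estimated at 20000 nM, with a likely range of 9000 nM to 45000 nM.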

Compound 4, half-maximal inhibitory concentration: 19800 nM
For compound 4 the middle estimate is 1.0-fold (0.00 log units) above the measured one; low and high end bracket the measured number.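

In this assay, putting bromo in place of chloro on the second core gives a 1.4-fold lower number from compound 3 to compound 4 (0.15 log units; within the scatter), a step too small for the assay to tell the two numbers apart. Set beside the same swap on the core of compound 1, the two steps agree: the same change on two cores in this assay, a 1.6-fold lower number (0.20 log units; within the scatter) from compound 1 to compound 2 and a 1.4-fold lower number (0.15 log units; within the scatter) from compound 3 to compound 4, 1.1-fold (0.05 log units) apart, within the scatter of two such steps

So, for these two pairs, the swap carries from one core to the other without any difference that can be read, but this is an agreement between two small steps, both within the ordinary spread of repeated measurements, and it does not show that bromo truly improves on chloro, that the swap would behave alike on any further core, or that the position of the halogen on the ring makes no difference, given that the swap does not sit in the same place in the two pairs.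

The compounds shown leave open how groups other than chloro and bromo would behave on this ring, such as an amine, a carboxylic acid or a methoxy group, on either core. As far as these compounds go, it also remains open what a longer chain in place of the 4-chlorobenzyl or 4-bromobenzyl group would do.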